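The source may report more compounds than this note shows. Statements on the series, on what has been measured and on what is new or still open speak of the compounds shown alone.

Working notes on the series. In a functional assay on COLO 205 cells (Homo sapiens) for cytotoxicity, read by MTT assay, with a stated time of 24 h (on this read-out lower numbers stand for stronger inhibition and higher numbers for weaker inhibition), compound 1 `COc1ccc(/C=C\C(=O)O)c(OCc2cn(-c3cccc(C#N)c3)nn2)c1CC=C(C)C` gives 26800 nM and stands at the higher of the two numbers recorded so far; compound 2 `COc1ccc(/C=C\C(=O)O)c(OCc2cn(-c3ccccc3C(=O)N3CCC(O)C3)nn2)c1CC=C(C)C` gives 25400 nM, a gap that lies within the scatter, so the two values show no difference. Compound 3 `COc1ccc(/C=C\C(=O)O)c(OCc2cn(-c3nc4ccccc4s3)nn2)c1CC=C(C)C` differs from compound 1 in one place: 1,3-benzothiazol-2-yl in place of 3-cyanophenyl on an aromatic nitrogen. Going by the values given here, no measured pair shows this change, so its effect is unknown. The expected step is a 1.1-fold lower number from compound 1 to compound 3 (0.05 log units; within the scatter), none beyond the scatter. Compound 3 is estimated at 24000 nM, with a range from 9000 nM to 60000 nM.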

Compound 3, half-maximal inhibitory concentration: 20200 nM
Estimate against measurement, compound 3: 1.2-fold (0.07 log units) above; the range from low to high includes it.
By their numbers in this assay, from the lowest: compounds 3, 2 and 1 (each within the scatter of the next).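

In this assay, going by these compounds alone, the step of a 1.3-fold lower number from compound 1 to compound 3 (0.12 log units; within the scatter) gives the first direct reading at this position on the aromatic nitrogen. It shows that 1,3-benzothiazol-2-yl can stand in place of 3-cyanophenyl with no difference beyond the scatter, so these two aromatic groups cannot be told apart here. Nothing available bears on why this is so.

Going by these compounds, whether any group at this position moves the number beyond the scatter remains open. A simple alkyl chain such as n-butyl, or a saturated amine such as piperidin-4-yl, would test this.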